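Benzyloxy for methoxy on a shared core

A few compounds are considered here, and "the series" means these few. Any claim that something is new, unique, unknown or untested is made for them only; others in the source may bear on it.

Among the compounds with values here, compound 1 `CCN(CC)CCCCOc1c(OC)cc2oc(-c3ccccc3)cc(=O)c2c1O` gives 17400 nM in a functional assay on BCG823 cells (Homo sapiens) for antiproliferative activity, read by MTT assay, with a stated time of 48 h (on this read-out lower numbers stand for stronger inhibition and higher numbers for weaker inhibition), the highest of the three numbers measured so far. Compound 2 `CCN(CC)CCCOc1c(OC)cc2oc(-c3ccccc3)cc(=O)c2c1O` gives 5700 nM, and compound 3 `COc1cc2oc(-c3ccccc3)cc(=O)c2c(O)c1OCCCCN1CCCC1` gives 10600 nM. The step of a 3.1-fold lower number from compound 1 to compound 2 (0.48 log units; beyond the scatter) is the only one of the three beyond the scatter; the steps of a 1.6-fold lower number from compound 1 to compound 3 (0.22 log units; within the scatter) and a 1.9-fold higher number from compound 2 to compound 3 (0.27 log units; within the scatter) both stay within it. Compound 4 `CCN(CC)CCCCOc1c(OCc2ccccc2)cc2oc(-c3ccccc3)cc(=O)c2c1O` differs from compound 1 by phenyl in place of hydrogen on a saturated chain carbon bound to an oxygen on an aromatic ring; cut one bond further out, the same change reads methoxy to benzyloxy. Within the data shown here, none of the measured steps touches this part of the molecule: all three alter the amine end of the chain, and the methoxy group is kept unchanged in compounds 1, 2 and 3 alike. The measured record therefore offers no direct guide to this change, and the expected step of a 1.2-fold lower number from compound 1 to compound 4 (0.09 log units; within the scatter) in this assay is set at none beyond the scatter, with wide uncertainty in both directions. Compound 4 is estimated to give 14000 nM, with a range from 4000 nM to 45000 nM.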

Compound 4, half-maximal inhibitory concentration: 4200 nM
Estimate against measurement, compound 4: 3.3-fold (0.52 log units) above; measured number inside the range.
By their numbers in this assay, from the lowest: compounds 4, 2, 3 and 1 (each within the scatter of the next, the first and the last beyond it).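

In this assay, methoxy to benzyloxy on the shared core gives a 4.1-fold lower number from compound 1 to compound 4 (0.62 log units; beyond the scatter), so this group, held unchanged in compounds 1, 2 and 3, is a second place where the number moves beyond the scatter, alongside the amine end of the chain. The earlier steps shown here showed only what happens at the amine end; this one shows that a phenyl on the saturated chain carbon bound to an oxygen on an aromatic ring is accepted and goes with a lower number, at least with the chain and amine of compound 1. Nothing in the available data says why the number falls with this change.

It remains open whether benzyloxy in place of methoxy would give a step of similar size with the chain of compound 2 or the pyrrolidin-1-yl group of compound 3, as the change is shown on one background only. The compounds shown also do not tell whether the phenyl ring itself matters, which an ethoxy or cyclohexylmethoxy group, or a benzyloxy group with fluorine on its phenyl, could test.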